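This account rests on a few compounds, and the source may have more. Where it says the series, first, only, none or still open, it means among the compounds named here.

Compound 1 `CSc1cnc2ccccc2c1SCC#CCO` is the reference point of this small set. For the measured compounds named here, in a functional assay on CCRF-CEM cells (Homo sapiens) for antiproliferative activity, with a stated time of 72 h (on this read-out lower numbers stand for stronger inhibition and higher numbers for weaker inhibition), compound 1 gives 2.3 ug/mL, the lowest of the two numbers so far; its nearest neighbour is compound 2 `CSc1cnc2ccccc2c1SCC#CCOC(=O)c1ccccc1`, which in this assay gives 22.2 ug/mL. That single measured step, a 9.7-fold higher number from compound 1 to compound 2 (0.98 log units; beyond the scatter), is the only one available.

The unmeasured compound 3 `CSc1cnc2ccccc2c1SCC#CCCl` differs from compound 1 by chloro in place of hydroxy on a saturated chain carbon bound to a triple-bonded carbon. The change removes the hydroxy group that compound 2 also loses, though compound 2 replaces it with a much larger benzoyl ester, whereas compound 3 puts in a single chlorine. The step from compound 1 to compound 2 therefore bears on the question only in part, and the increase of a 9.7-fold higher number from compound 1 to compound 2 (0.98 log units; beyond the scatter) is taken as an upper guide rather than a direct forecast.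

Compound 3 is accordingly expected to show a higher number than compound 1 in this assay, but by less than compound 2 did, an estimated step of a 2.2-fold higher number from compound 1 to compound 3 (0.34 log units; beyond the scatter). The estimate for compound 3 in this assay is 5 ug/mL, with a range from 1.5 ug/mL to 15 ug/mL.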

Compound 3, concentration for 50% inhibition: 2.5 ug/mL
Compound 3: middle estimate off by 2.0-fold (0.30 log units), on the high side; the range from low to high includes it.
By their numbers in this assay, from the lowest: compounds 1 and 3 (each within the scatter of the next); then compound 2.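

In this assay, chloro in place of hydroxy on a saturated chain carbon bound to a triple-bonded carbon gives a 1.1-fold higher number from compound 1 to compound 3 (0.04 log units; within the scatter), so compound 1 and compound 3 cannot be told apart on this read-out. For the compounds shown here, this is the first sign that the position tolerates losing the hydroxy: the change removes the hydrogen-bond donor and acceptor counted for that group, yet the step stays within the scatter, unlike the benzoyl step, a 9.7-fold higher number from compound 1 to compound 2 (0.98 log units; beyond the scatter), which lies beyond it. No measurement shown here explains why the exchange of hydroxy for chloro leaves the read-out unchanged within the scatter.

The compounds shown leave open whether other small groups at this place, such as an amine, a methoxy group or a fluorine atom, would also sit within the scatter of compound 1. They also leave open whether the benzoyl step depends on the size of the ester, which a smaller acetyl ester would test, and whether a longer chain in place of the 4-chlorobut-2-yn-1-yl group would keep the same level.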